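The compounds below may be only part of what the source reports. "The series", "measured", "known", "first", "only" and "open" are said of these compounds alone.

Going by the values given here, compound 2, with the structure `CNc1ncnc2c(CNc3cc(NC(=O)c4ccc(Cl)c(C(F)(F)F)c4)ccc3C)cccc12`, is one of two compounds measured in a functional assay on A375P cells (Homo sapiens) for cytotoxicity, read by MTT assay, with a stated time of 24 h; a lower number here means a stronger inhibitor, a higher number a weaker inhibitor. In this assay compound 2 gives 9700 nM, the highest number of the two. Compound 1, built as `CNc1ncnc2c(CNc3cc(NC(=O)c4cc(C(F)(F)F)cc(C(F)(F)F)c4)ccc3C)cccc12`, gives 769 nM in this assay, a markedly lower number than compound 2, so compound 1 is the stronger inhibitor of the pair, and the gap lies beyond the scatter of repeated measurements.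

Compound 3, drawn as `CNc1ncnc2c(CNc3cc(NC(=O)c4ccc(Br)s4)ccc3C)cccc12`, has not yet been measured in this assay. It differs from compound 2 in one place: 5-bromothiophen-2-yl in place of 4-chloro-3-(trifluoromethyl)phenyl on a carbonyl carbon. Two measured points give no firm rule for what this change does, so the expectation is a modest step. The step from compound 2 to compound 3 is expected to be a 1.5-fold higher number from compound 2 to compound 3 (0.19 log units; within the scatter), a slight weakening at most. For compound 3 the estimate in this assay is 15000 nM, within a range from 4000 nM to 50000 nM.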

Compound 3, half-maximal inhibitory concentration: 10500 nM
The estimate for compound 3 lay 1.4-fold (0.15 log units) above the measured number; measured number inside the range.
By their numbers in this assay, from the lowest: compound 1; then compounds 2 and 3 (each within the scatter of the next).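

In this assay, placing 5-bromothiophen-2-yl instead of 4-chloro-3-(trifluoromethyl)phenyl on the carbonyl carbon gives a 1.1-fold higher number from compound 2 to compound 3 (0.03 log units; within the scatter) and so the two compounds cannot be told apart. Going by these compounds alone, this is the first comparison at this position, and it shows that the aromatic group there can be exchanged for one with a five-membered ring, a sulfur atom, a bromine and fewer heavy atoms without a difference that can be read in this pair. No measured evidence accounts for this result.

As far as these compounds go, it remains open whether the bromine matters, since a thiophene without it, or a chlorine in its place, would be needed to tell. From the compounds shown here alone, how a non-aromatic group such as piperidine, or a pyridine ring, on the same carbonyl carbon would read in this assay is also open.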